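Benzyl swap on the shared core of compound 1

The source may hold more compounds than are shown below. What is called first, only, known or untested is meant among the compounds shown, and "the series" means these compounds.

Compound 1 `COc1cccc(CNc2ncnc3c2ncn3[C@@H]2O[C@H](CO)[C@@H](O)[C@H]2O)c1OC` is tested in a functional assay on HOS cells (Homo sapiens) for antiproliferative activity, with a stated time of 72 h; a lower number here means a stronger inhibitor, a higher number a weaker inhibitor. In this assay compound 1 gives only a limit of the assay, > 166000 nM. Compound 3 `COc1cc(CNc2ncnc3c2ncn3[C@@H]2O[C@H](CO)[C@@H](O)[C@H]2O)cc(OC)c1O` likewise reaches only a limit in this assay, > 166000 nM. Compound 2 `OC[C@H]1O[C@@H](n2cnc3c(NCc4cc(F)cc(F)c4)ncnc32)C(O)C1O` has no result reported in this assay, "not determined" (no result reported). Compound 1 thus stands at the assay limit without a number of its own, one further compound sits at the same limit, and the third entry carries no number at all; (the limit of > 166000 nM in this assay, at which 2 of the 3 values shown sit). Compound 4 `OC[C@H]1O[C@@H](n2cnc3c(NCc4ccc(C(F)(F)F)cc4)ncnc32)[C@H](O)[C@@H]1O` is not yet measured and differs from compound 1 by 4-(trifluoromethyl)phenyl in place of 2,3-dimethoxyphenyl on a saturated chain carbon bound to a nitrogen on an aromatic ring. Going by the values given here, no step between measured compounds exists here, so the size and direction of this change in this assay are open; two limits give no direction. For compound 4 an activity of 100000 nM is expected, within 20000 nM to 250000 nM. The expected step is an at least 1.6-fold lower number from compound 1 to compound 4 (0.22 log units; that floor lies within the scatter), most likely ending again at a limit.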

Compound 4, half-maximal inhibitory concentration: > 166000 nM
Compound 4: only a limit was reported (the forecaster's own chance of this, stated with the estimate: 60%); middle value at least 1.6-fold (0.22 log units) from the limit.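

Compound 1 and compound 4 both end at a limit in this assay, so no step between them can be read: the limit of > 166000 nM in this assay, at which 3 of the 4 values shown sit.

The compounds shown leave open whether any swap on the shared core gives a measurable number in this assay.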